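Aryl replacement on the shared core: compound 2 to compound 3

The compounds below may be only part of what the source reports. "The series", "measured", "known", "first", "only" and "open" are said of these compounds alone.

Measured so far:
- compound 1, `COc1ccc2c(OCc3nnc4sc(-c5ccc[nH]5)nn34)ccnc2c1`: 313 nM
- compound 2, `COc1ccc2c(OCc3nnc4sc(-c5cc6cc(F)ccc6[nH]5)nn34)ccnc2c1`: "not determined" (no result reported)

In a functional assay on EBC-1 cells (Homo sapiens) for antiproliferative activity, with a stated time of 72 h (a higher number here means a weaker inhibitor, a lower number a stronger inhibitor), compound 1 gives 313 nM. Compound 2 carries the same core and its result in this assay is "not determined" (no result reported); its standing is therefore unknown, and nothing can be said about the distance between compound 1 and compound 2 on the numbers shown.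

Compound 3, `COc1cccc(-c2nn3c(COc4ccnc5cc(OC)ccc45)nnc3s2)c1`, is the next compound of the series. It differs from compound 2 in one place: 3-methoxyphenyl in place of 5-fluoro-1H-indol-2-yl on an aromatic carbon. For the measured compounds named here, no step between two measured compounds covers this change, and compound 2 itself has no value to step from, so the direction and size of the change in this assay cannot be read from the data. Going by the values given here, the only anchor is compound 1 with its 313 nM, a close relative on the same core.

Compound 3 is expected to fall near 500 nM, within a broad range of 100 nM to 3000 nM, an estimate that rests on compound 1 alone.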

Compound 3, half-maximal inhibitory concentration: 472 nM
For compound 3 the middle estimate is 1.1-fold (0.03 log units) above the measured one; the measured number falls inside the stated range.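

In this assay, 3-methoxyphenyl in place of 1H-pyrrol-2-yl on an aromatic carbon gives a 1.5-fold higher number from compound 1 to compound 3 (0.18 log units; within the scatter), so this replacement on the shared core does not separate the two compounds. For the compounds shown here, the first readable step at this position therefore shows that a six-membered aromatic ring of carbon only, carrying methoxy, can stand here without a change beyond the scatter, while the step from compound 2 to compound 3 cannot be read with no value for compound 2. No measurement is available to explain this result.

Going by these compounds, whether the 5-fluoro-1H-indol-2-yl group of compound 2 fits the same picture stays open. Also open, on these data alone, is whether an amine, a carboxylic acid or a longer alkoxy chain in place of the methoxy group of compound 3 would hold the number or move it beyond the scatter.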